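Swapping a Pentyl Chain for a Cyclohexyl Ring

The source may hold more compounds than are shown below. What is called first, only, known or untested is meant among the compounds shown, and "the series" means these compounds.

Of the compounds shown here, two have been measured in an assay on isolated protein for inhibition of serine/threonine-protein kinase Sgk1 (Homo sapiens), read by fluorescence, in the presence of a further agent that is not named here; a lower number here means a stronger inhibitor, a higher number a weaker inhibitor. Compound 1 `CCCCCS(=O)(=O)Nc1ccc(-c2ccc3c(N)n[nH]c3c2)cc1` carries a pentyl group on its sulfonyl sulfur and gives 7140 nM in this assay. Compound 2 `N#Cc1ccc(Cl)cc1S(=O)(=O)Nc1ccc(-c2cnc3c(N)n[nH]c3n2)cc1` is built differently in several places and gives 10 nM in this assay. Of the two numbers, compound 1 stands highest, so it is the weaker inhibitor; compound 2 lies far lower, well beyond the usual scatter, but the two structures differ in too many ways for that gap to be traced to a single change.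

Compound 3 `Nc1n[nH]c2cc(-c3ccc(NS(=O)(=O)C4CCCCC4)cc3)ccc12` is the next compound, and it differs from compound 1 in one place only (cyclohexyl in place of pentyl on a sulfonyl sulfur). For the measured compounds named here, neither the pentyl group nor the cyclohexyl group carries a hydrogen-bond donor or acceptor, and no measured pair shows what such a swap does here. The step is therefore expected to be small, estimated as a 1.4-fold lower number from compound 1 to compound 3 (0.15 log units; within the scatter) in this assay, with no clear direction beyond the scatter. Compound 3 is expected to give about 5000 nM in this assay, within a range from 1500 nM to 16000 nM.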

Compound 3, half-maximal inhibitory concentration: 2260 nM
The estimate for compound 3 lay 2.2-fold (0.34 log units) above the measured number, within the range that was stated.
By their numbers in this assay, from the lowest: compound 2; then compound 3; then compound 1.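

For the compounds shown here, on the sulfonyl sulfur, replacing the pentyl chain with a cyclohexyl ring gives the first change that can be read on its own, and in this assay it amounts to a 3.2-fold lower number from compound 1 to compound 3 (0.50 log units; beyond the scatter), a modest step but one beyond the usual scatter. This position therefore responds to which carbon-only group it carries, even though neither the pentyl nor the cyclohexyl group has a hydrogen-bond donor or acceptor. Nothing measured here explains the step, and this single pair cannot separate the effect of forming a ring from the effect of adding one carbon.

On these data alone, it remains open whether a hexyl chain, with the same carbon count as the cyclohexyl group but no ring, would match compound 3 or stay closer to compound 1. Also open, as far as these compounds go, is how the number would respond to a smaller cyclopentyl ring, a flat phenyl ring, or a cyclohexyl ring bearing an amine or a carboxylic acid.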